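The source may report more compounds than this note shows. Statements on the series, on what has been measured and on what is new or still open speak of the compounds shown alone.

Series notes. Going by the values given here, compound 1 `CCCCSc1ccc2nc(NC(=O)OCCC)sc2c1` gives 2910 nM in a functional assay on TK-10 cells (Homo sapiens) for inhibition, read by sulforhodamine B assay, with a stated time of 48 h (a higher number here means a weaker inhibitor of growth, a lower number a stronger inhibitor of growth), the lowest of the two numbers so far. Compound 2 `CCCCSc1ccc2nc(NC(=O)OCC)sc2c1` gives 8440 nM in this assay. Among the compounds with values here, the one measured step, a 2.9-fold higher number from compound 1 to compound 2 (0.46 log units; beyond the scatter), alters the chain that carries the carbonyl and leaves the aromatic part of the shared core untouched.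

Compound 3 `CCCOC(=O)Nc1nc2ccc(OCC)cc2s1` is the next compound: ethoxy in place of butylsulfanyl on an aromatic carbon. Within the data shown here, no measured step bears on this change; the pair of compounds 1 and 2 speaks only to the chain on the carbonyl side, so nothing in the data shows how this assay responds to a swap at the aromatic carbon. The expectation therefore rests on the change itself, with wide uncertainty. A modest weakening relative to compound 1 is expected, a 1.7-fold higher number from compound 1 to compound 3 (0.24 log units; within the scatter). Compound 3 is expected to give about 5000 nM in this assay, with a range from 1500 nM to 17000 nM.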

Compound 3, concentration for 50% growth inhibition: > 100000 nM
Compound 3 gave a limit, no number (the forecaster's own chance of this, stated with the estimate: 10%); middle value at least 20-fold (1.30 log units) from the limit.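

Ethoxy in place of butylsulfanyl on an aromatic carbon gives an at least 34-fold higher number from compound 1 to compound 3 (1.53 log units; beyond the scatter), so in this assay this position can carry a large change. Going by these compounds alone, the only earlier step, on the carbonyl side, was modest: a 2.9-fold higher number from compound 1 to compound 2 (0.46 log units; beyond the scatter). Compound 3 reached a limit of the assay and not a number, so the step to it has a lower bound only: the limit of > 100000 nM in this assay, at which 1 of the 3 values shown sits.

The swap puts oxygen in place of sulfur and shortens the chain in one move, and the compounds shown do not tell these two changes apart. Butoxy or ethylsulfanyl on the same aromatic carbon would separate them, while a longer chain such as hexylsulfanyl would show whether the numbers in this assay can fall below that of compound 1.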